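Quinoline-oxadiazole series: aryl variation at the oxadiazole

This account rests on a few compounds, and the source may have more. Where it says the series, first, only, none or still open, it means among the compounds named here.

Measured so far in an ADME assay on A549 cells (Homo sapiens) for cytotoxicity, read by MTT assay, with a stated time of 48 h; a lower number here means a stronger inhibitor, a higher number a weaker inhibitor:
- compound 1 `Cc1ccc(-c2nnc(-c3cc4ccccc4nc3C)o2)cc1`: 175 ug/mL
- compound 2 `Cc1nc2ccccc2cc1-c1nnc(-c2ccc(OC(F)(F)F)cc2)o1`: 91.1 ug/mL
- compound 3 `Cc1nc2ccccc2cc1-c1nnc(-c2ccc(C(C)C)cc2)o1`: 103 ug/mL

Compound 1 gives the highest of the three numbers, but its gaps to the other two are small: a 1.9-fold lower number from compound 1 to compound 2 (0.28 log units; within the scatter) and a 1.7-fold lower number from compound 1 to compound 3 (0.23 log units; within the scatter) are both within the scatter, and between compounds 2 and 3 the difference is a 1.1-fold higher number from compound 2 to compound 3 (0.05 log units; within the scatter), also within the scatter. Across these three compounds the shared core carries a substituted phenyl on the oxadiazole, and swapping the substituent on that phenyl has not moved the number in this assay beyond repeat variation.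

Compound 4 `Cc1nc2ccccc2cc1-c1nnc(-c2cccnc2)o1` changes a different thing: pyridin-3-yl in place of 4-methylphenyl on an aromatic carbon. For the measured compounds named here, no measured step replaces the whole aryl group, so the steps from compound 1 to compounds 2 and 3 bear on it only as a general sign that this position has so far tolerated change without a shift in this assay. On that basis no step beyond the scatter is expected for compound 4, and the expected step is a 1.3-fold lower number from compound 1 to compound 4 (0.13 log units; within the scatter). Compound 4 is estimated at 130 ug/mL, with a range from 55 ug/mL to 310 ug/mL.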

Compound 4, half-maximal inhibitory concentration: 139 ug/mL
For compound 4 the middle estimate is 1.1-fold (0.03 log units) below the measured one; the range from low to high includes it.
By their numbers in this assay, from the lowest: compounds 2, 3, 4 and 1 (each within the scatter of the next).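

In this assay, exchanging the whole aryl group rather than a substituent on it gives a 1.3-fold lower number from compound 1 to compound 4 (0.10 log units; within the scatter), so this change at the aromatic carbon next to the ring oxygen stays within repeat variation. Compounds 2 and 3 kept the phenyl ring and varied only its substituent, whereas compound 4 shows that pyridin-3-yl, a six-membered aromatic ring with a hetero atom and one hydrogen-bond acceptor, can stand in place of 4-methylphenyl without a step beyond the scatter in this assay. No supporting measurement is available to explain this result.

Since every step measured so far lies within the scatter, the compounds shown do not establish what kind of change at this position would produce a clear step in this assay. Still open, on these data alone, are pyridin-2-yl and pyridin-4-yl, an aryl group carrying an amine or a carboxylic acid, and a piperidine ring or a longer alkyl chain in place of the aryl group.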